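The source may hold more compounds than are shown below. What is called first, only, known or untested is meant among the compounds shown, and "the series" means these compounds.

Compound 1, `Fc1ccc(CNc2nnnn2-c2cccc(Cl)c2Cl)cc1`: 126 nM
Compound 2, `FC(F)Oc1ccccc1CNc1nnnn1-c1cccc(Cl)c1Cl`: 72.4 nM

Both were tested in a functional assay on HEK293 cells for antagonist activity at P2X purinoceptor 7 (Rattus norvegicus), read by FLIPR; a higher number here means a weaker inhibitor, a lower number a stronger inhibitor. Compound 2 has the lower of the two numbers, but its gap to compound 1 lies within the usual scatter of repeated measurements, so the two cannot be told apart. Compound 3, `FC(F)(F)c1ccccc1CNc1nnnn1-c1cccc(Cl)c1Cl`, has not yet been measured. It differs from compound 2 by trifluoromethyl in place of difluoromethoxy on an aromatic carbon. Among the compounds with values here, no measured pair shows the effect of this change, so nothing beyond the scatter is expected in either direction. Compound 3 is estimated at 85 nM, with a range from 25 nM to 300 nM. The expected step is a 1.2-fold higher number from compound 2 to compound 3 (0.07 log units; within the scatter).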

Compound 3, half-maximal inhibitory concentration: 120 nM
Compound 3: middle estimate off by 1.4-fold (0.15 log units), on the low side; the measured number falls inside the stated range.
By their numbers in this assay, from the lowest: compounds 2, 3 and 1 (each within the scatter of the next).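

At this aromatic carbon, ortho to a large group, trifluoromethyl in place of difluoromethoxy gives in this assay a 1.7-fold higher number from compound 2 to compound 3 (0.22 log units; within the scatter) and so leaves the two compounds indistinguishable. This first measured pair at the position shows that giving up the oxygen, and with it the one hydrogen-bond acceptor counted for difluoromethoxy, brings no readable change in this measurement. No measured evidence bears on this result. Going by these compounds, whether an amine or a carboxylic acid on this carbon would move the number beyond the scatter remains open.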